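Hydrazone series: carbonyl aryl replacement toward a 2-aminophenyl

The source may hold more compounds than are shown below. What is called first, only, known or untested is meant among the compounds shown, and "the series" means these compounds.

Working notes on the carbonyl-aryl variation within the shared core. Within the data shown here, compound 2 `O=C(N/N=C/C1=C(Cl)c2ccccc2CCC1)c1cccc(Cl)c1` in a functional assay (MiaPaCa cells, Homo sapiens) for inhibition, read by sulforhodamine B assay, with a stated time of 48 h (a lower number here means a stronger inhibitor of growth, a higher number a weaker inhibitor of growth), gives 78400 nM, the highest of the two numbers measured so far. Among the measured compounds shown here, its nearest neighbour is compound 1 `Cc1ccc(C(=O)N/N=C/C2=C(Cl)c3ccccc3CCC2)cc1`, which in this assay gives 10000 nM; the single measured step, a 7.8-fold higher number from compound 1 to compound 2 (0.89 log units; beyond the scatter), is the only guide to how the aryl group on the carbonyl carbon moves the numbers in this assay.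

Compound 3 `Nc1ccccc1C(=O)N/N=C/C1=C(Cl)c2ccccc2CCC1` is not yet measured. It differs from compound 2 in one place: 2-aminophenyl in place of 3-chlorophenyl on a carbonyl carbon. For the measured compounds named here, no measured step introduces an amino-bearing aryl group, so the direction rests only on the observation that exchanging the aryl group shifted the number markedly from compound 1 to compound 2.

Given that the measured aryl exchange was beyond the scatter, a shift of similar size is expected here, and compound 3 is estimated to land below compound 2, the step of a 3.1-fold lower number from compound 2 to compound 3 (0.50 log units; beyond the scatter). Compound 3 is therefore expected to give about 25000 nM in this assay, within a range from 6000 nM to 100000 nM.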

Compound 3, concentration for 50% growth inhibition: 65100 nM
Compound 3: middle estimate off by 2.6-fold (0.42 log units), on the low side, and the stated range covers the measured number.
By their numbers in this assay, from the lowest: compound 1; then compounds 3 and 2 (each within the scatter of the next).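

In this assay the exchange of 3-chlorophenyl for 2-aminophenyl on the carbonyl carbon gives a 1.2-fold lower number from compound 2 to compound 3 (0.08 log units; within the scatter), so this position does not separate these two aryl groups, although the entering group carries a hydrogen-bond donor and a hydrogen-bond acceptor and the leaving group carries neither. Starting from the 4-methylphenyl of compound 1, the same 2-aminophenyl gives a 6.5-fold higher number from compound 1 to compound 3 (0.81 log units; beyond the scatter), in the same direction as a 7.8-fold higher number from compound 1 to compound 2 (0.89 log units; beyond the scatter), so compound 1 now holds the lowest number of the three and both other aryl groups stand on the weaker side of it. There is no measurement here that accounts for either the shared level of compound 2 and compound 3 or the gap to compound 1.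

Still open, going by these compounds, is whether the advantage of compound 1 belongs to the methyl group itself or to its place on the ring, a question that a 3-methylphenyl or a 4-chlorophenyl on the same carbonyl carbon would address. Also open, on these data alone, is how this position responds to an unsubstituted phenyl, a carboxylic acid on the aryl ring or a longer alkyl chain in place of the methyl group.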